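Two Cores, One Recurring Aryl Swap

The compounds below may be only part of what the source reports. "The series", "measured", "known", "first", "only" and "open" are said of these compounds alone.

Compound 1 `COc1ccc(C2=NN(C(=O)C3COc4ccccc4O3)C(c3cccc(F)c3)C2)cc1` and compound 2 `COc1ccc(C2=NN(C(=O)C3COc4ccccc4O3)C(c3ccc(OC)cc3)C2)cc1` share one core, while compound 3 `O=C(c1ccc2c(c1)OCCO2)N1N=C(c2ccccc2)CC1c1cccc(F)c1` and compound 4 `COc1ccc(C2CC(c3ccccc3)=NN2C(=O)c2ccc3c(c2)OCCO3)cc1` share another. In a functional assay on WM 266-4 cells (Homo sapiens) for inhibition, read by MTT assay, with a stated time of 24 h (a lower number here means a stronger inhibitor of growth, a higher number a weaker inhibitor of growth), compound 1 gives 6720 nM, and compound 2 gives 11000 nM. The change between them is 4-methoxyphenyl in place of 3-fluorophenyl on a saturated ring carbon, and it produced a 1.6-fold higher number from compound 1 to compound 2 (0.21 log units; within the scatter). In this assay compound 3 gives 1840 nM, the lowest of the three numbers, with compound 1 nearest and compound 2 furthest, both beyond the scatter. The difference between the core of compound 1 and the core of compound 3 is not broken down here.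

Compound 4 has not yet been measured in this assay. It differs from compound 3 by 4-methoxyphenyl in place of 3-fluorophenyl on a saturated ring carbon. This is the same kind of change as that between compound 1 and compound 2; the surroundings differ only in that the ring atom two ring bonds away bears a phenyl group in compound 3, where in compound 1 it bears a 4-methoxyphenyl group. In this assay compound 4 is expected to lie a step of a 1.6-fold higher number from compound 3 to compound 4 (0.21 log units; within the scatter) away because the same kind of change earlier gave a 1.6-fold higher number from compound 1 to compound 2 (0.21 log units; within the scatter), a step within the scatter. The estimate for compound 4 is therefore 3000 nM, with a likely range from 1200 nM to 7500 nM.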

Compound 4, concentration for 50% growth inhibition: 8370 nM
The estimate for compound 4 lay 2.8-fold (0.45 log units) below the measured number, and the stated range ends below it.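

In this assay, putting 4-methoxyphenyl in place of 3-fluorophenyl on the saturated ring carbon gave a 4.5-fold higher number from compound 3 to compound 4 (0.66 log units; beyond the scatter), so on this core the change clearly weakens growth inhibition. Its size did not carry over from the core of compound 1 to the core of compound 3, and a step measured on one core was a poor guide to the step on the other: the same change on two cores in this assay, a 1.6-fold higher number (0.21 log units; within the scatter) from compound 1 to compound 2 and a 4.5-fold higher number (0.66 log units; beyond the scatter) from compound 3 to compound 4, 2.8-fold (0.44 log units) apart, beyond the scatter of two such steps. This does not show which structural difference sets the two steps apart, since the cores differ in more than one place, and with one pair on each core it cannot be said whether the larger step is typical of the core of compound 3 or particular to this pair.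

The compounds shown leave open whether the gap follows the phenyl group of compound 3, where compound 1 bears a 4-methoxyphenyl group, or the remaining difference between the two cores. They also leave open how either core would respond if the group on the saturated ring carbon were a phenyl ring carrying an amine or a carboxylic acid, so the comparison rests on 3-fluorophenyl and 4-methoxyphenyl alone.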